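The source may hold more compounds than are shown below. What is called first, only, known or untested is meant among the compounds shown, and "the series" means these compounds.

Among the measured compounds shown here, compound 2, `COc1cc(Cl)cc(-c2nn(-c3cccc(NC(=O)Nc4ccc(Cl)c(C(F)(F)F)c4)c3)cc2-c2ccncc2)c1`, is one of two compounds measured in a functional assay on DU-145 cells (Homo sapiens) for inhibition, read by sulforhodamine B assay, with a stated time of 48 h, tested at 0.1 uM; a lower number here means a stronger effect, a higher number a weaker effect of the compound at the concentration tested; it gives 98%. Compound 1, `O=C(Nc1cccc(-n2cc(-c3ccncc3)c(-c3cc(O)cc(Cl)c3)n2)c1)Nc1ccc(Cl)c(C(F)(F)F)c1`, gives 99% in this assay. For the measured compounds named here, compound 2 stands at the lower of these two numbers, but the only measured step, a number 1 percentage points lower from compound 1 to compound 2 (within the scatter), lies within the scatter, so the two compounds cannot be told apart on this read-out.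

Compound 3, `COc1cc(Cl)cc(-c2nn(-c3cccc(NC(=O)Nc4cccc(C(F)(F)F)c4)c3)cc2-c2ccncc2)c1`, has not yet been measured in this assay. It differs from compound 2 in one place: hydrogen in place of chloro on an aromatic carbon. Going by the values given here, no measured step touches the urea end of the molecule where this change sits; the one step available, a number 1 percentage points lower from compound 1 to compound 2 (within the scatter), concerns a different part of the compound and was itself within the scatter. With both measured compounds giving read-outs close to the top of the scale, there is no evidence here that small changes move this read-out at all.

Compound 3 is therefore expected to give a read-out near those of its neighbours, with a step of a number 1 percentage points lower from compound 2 to compound 3 (within the scatter) that stays within the scatter. The estimate for compound 3 in this assay is 97%, ranging from 86% to 106%.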

Compound 3, a percentage reported as activity, at one concentration (the size of the read-out at that concentration, not a potency): 99%
Beside the measured number, compound 3's estimate is 2 percentage points below it, and the stated range covers the measured number.
By their numbers in this assay, from the lowest: compounds 2, 1 and 3 (each within the scatter of the next).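

At the urea end of the molecule, on an aromatic carbon ortho to a trifluoromethyl group and para to a large group, hydrogen in place of chloro gives a number 1 percentage points higher from compound 2 to compound 3 (within the scatter) in this assay and so leaves the read-out indistinguishable from that of the chloro compound. Among the compounds shown here, the earlier compounds offered only a number 1 percentage points lower from compound 1 to compound 2 (within the scatter) at the other end of the molecule, so this is the first sign that the 4-chloro-3-(trifluoromethyl)phenyl group can give way to 3-(trifluoromethyl)phenyl with no step beyond the scatter, at the single concentration tested. Nothing available here explains this result.

The compounds shown leave open whether a different replacement on this carbon, such as an amine or a carboxylic acid, or a change of the neighbouring trifluoromethyl group to a methyl group, would give a step beyond the scatter. They also leave open whether the chloro group matters under other conditions, as all three read-outs lie close together at one concentration and one stated time and so say nothing about potency.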